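Aryl variation on the aromatic nitrogen: compound 4 outlook

The source may report more compounds than this note shows. Statements on the series, on what has been measured and on what is new or still open speak of the compounds shown alone.

compound 1 `N#CC1=C(N)Oc2c(c3nc4ccccc4nc3c3ccccc23)C12C(=O)N(Cc1cnnn1-c1ccc(F)cc1)c1ccccc12` — in a functional assay on HepG2 cells (Homo sapiens) for antiproliferative activity, read by MTT assay, with a stated time of 48 h (on this read-out lower numbers stand for stronger inhibition and higher numbers for weaker inhibition), compound 1 gives > 50000 nM
compound 2 `N#CC1=C(N)Oc2c(c3nc4ccccc4nc3c3ccccc23)C12C(=O)N(Cc1cnnn1-c1cccc(Cl)c1)c1ccccc12` — in this assay compound 2 gives > 50000 nM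
compound 3 `N#CC1=C(N)Oc2c(c3nc4ccccc4nc3c3ccccc23)C12C(=O)N(Cc1cnnn1-c1ccc([N+](=O)[O-])cc1)c1ccccc12` — in this assay compound 3 gives > 50000 nM

Each of these values is a limit of this assay, not a number. Compound 2 thus stands only at a limit, as do the other two, all three at the limit of > 50000 nM in this assay, at which 3 of the 3 values shown sit. Compound 4 `N#CC1=C(N)Oc2c(c3nc4ccccc4nc3c3ccccc23)C12C(=O)N(Cc1cnnn1-c1ccc(S(N)(=O)=O)cc1)c1ccccc12` differs from compound 2 by 4-sulfamoylphenyl in place of 3-chlorophenyl on an aromatic nitrogen. The steps bearing on this change, a step that the two limits leave unreadable from compound 1 to compound 2, a step that the two limits leave unreadable from compound 1 to compound 3 and a step that the two limits leave unreadable from compound 2 to compound 3, are all unreadable; both ends of each sit at the limit of > 50000 nM in this assay, at which 3 of the 3 values shown sit. Within the data shown here, nothing measured so far separates the aryl groups on the aromatic nitrogen. Compound 4 is therefore expected to remain near the same limit, with the step of a number no higher from compound 2 to compound 4 (the limit leaves the size open) estimated as small or none. Compound 4 is estimated at 50000 nM, between 15000 nM and 200000 nM.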

Compound 4, half-maximal inhibitory concentration: 42200 nM
Compound 4: middle estimate off by 1.2-fold (0.07 log units), on the high side, within the range that was stated.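

Of the aryl groups shown on this aromatic nitrogen, only 4-sulfamoylphenyl gives a readable number in this assay, while compounds 1, 2 and 3 each remain at a limit: the limit of > 50000 nM in this assay, at which 3 of the 4 values shown sit. Read against those limits, the change gives an at least 1.1-fold lower number from compound 2 to compound 4 (0.07 log units; that floor lies within the scatter), an at least 1.1-fold lower number from compound 3 to compound 4 (0.07 log units; that floor lies within the scatter) and an at least 1.1-fold lower number from compound 1 to compound 4 (0.07 log units; that floor lies within the scatter). As far as these compounds go, these floors do not establish a separation among the aryl groups, as the true size of each step stays open.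

The compounds shown leave open whether an amine or a carboxylic acid in place of sulfamoyl would give a number further from the limit.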